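This account rests on a few compounds, and the source may have more. Where it says the series, first, only, none or still open, it means among the compounds named here.

Measured so far in a functional assay on Bel7402/5-FU cells (Homo sapiens) for cytotoxicity, read by MTT assay, with a stated time of 72 h; a higher number here means a weaker inhibitor, a lower number a stronger inhibitor:
Compound 1 (`O=C1C=CCC/C1=C\C=C\c1ccccc1`) gives 4200 nM
Compound 2 (`O=C1C=CCC/C1=C\C=C\c1ccc(Cl)cc1`) gives 3200 nM
Compound 3 (`O=C1C=CCC/C1=C\C=C\c1ccccc1[N+](=O)[O-]`) gives 5200 nM

Compound 3, at 5200 nM in this assay, lies within the scatter of both compound 1 and compound 2. The step to compound 4 (`COc1ccccc1/C=C/C=C1\CCC=CC1=O`) puts methoxy in place of nitro on an aromatic carbon, ortho to a large group (methoxy in place of nitro on an aromatic carbon). Among the compounds with values here, two measured steps bear on it: nitro in place of hydrogen (a 1.2-fold higher number from compound 1 to compound 3 (0.09 log units; within the scatter)) and chloro in place of hydrogen (a 1.3-fold lower number from compound 1 to compound 2 (0.12 log units; within the scatter)). Within the data shown here, both stayed within the scatter, though no measured compound carries methoxy. No step beyond the scatter is therefore expected in this assay, and the estimated step is small (a 1.2-fold lower number from compound 3 to compound 4 (0.09 log units; within the scatter)). The estimate for compound 4 is 4200 nM, with an expected range from 2000 nM to 8500 nM.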

Compound 4, half-maximal inhibitory concentration: 2500 nM
Compound 4: the middle estimate sits 1.7-fold (0.23 log units) above what was measured; low and high end bracket the measured number.
By their numbers in this assay, from the lowest: compounds 4, 2, 1 and 3 (each within the scatter of the next, the first and the last beyond it).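

In this assay, within the data shown here, replacing nitro with methoxy on this aromatic carbon gives the first step beyond the scatter in this set, a modest one: a 2.1-fold lower number from compound 3 to compound 4 (0.32 log units; beyond the scatter) is what separates the two groups. Against hydrogen at the same place, methoxy stays within the scatter, with a 1.7-fold lower number from compound 1 to compound 4 (0.23 log units; within the scatter) as its step, so the difference appears only between the two substituents. Nothing measured here accounts for that difference.

Going by these compounds, whether an amine or a carboxylic acid on this aromatic carbon would move the number further from that of compound 1 remains open. So does whether methoxy would give a similar number on another aromatic carbon.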